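Hydrazone aryl variation on the shared core

The compounds below may be only part of what the source reports. "The series", "measured", "known", "first", "only" and "open" are said of these compounds alone.

Measured so far:
compound 1, `CN(C)CCn1cnnc1-c1cc(Oc2ccc(NC(=O)N/N=C/c3cc(C(C)(C)C)cc(C(C)(C)C)c3O)cc2F)ccn1`: 680 nM in a functional assay on HT-29 cells (Homo sapiens) for cytotoxicity, read by MTT assay, with a stated time of 72 h; a lower number here means a stronger inhibitor, a higher number a weaker inhibitor
compound 2, `CN(C)CCn1cnnc1-c1cc(Oc2ccc(NC(=O)N/N=C/c3ccccc3O[N+](=O)[O-])cc2F)ccn1`: 950 nM in this assay

Compound 2 gives the higher of the two numbers in this assay, but its gap to compound 1 lies within the scatter, so the two cannot be ordered. Compound 3, `CN(C)CCn1cnnc1-c1cc(Oc2ccc(NC(=O)N/N=C/c3cc(Br)c(O)c(Br)c3)cc2F)ccn1`, awaits measurement in this assay. It differs from compound 2 by 3,5-dibromo-4-hydroxyphenyl in place of 2-(nitrooxy)phenyl on a carbon with a double bond to nitrogen. Because compound 1 with 680 nM sits within the scatter of compound 2, no step beyond the scatter is expected for this change, a 1.4-fold lower number from compound 2 to compound 3 (0.13 log units; within the scatter), with a slight drift toward lower numbers at most. Compound 3 is expected near 700 nM, between 300 nM and 1600 nM.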

Compound 3, half-maximal inhibitory concentration: 2670 nM
Compound 3: the middle estimate sits 3.8-fold (0.58 log units) below what was measured; the whole stated range lies below it.
By their numbers in this assay, from the lowest: compounds 1 and 2 (each within the scatter of the next); then compound 3.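

In this assay, going by these compounds alone, the aryl group on a carbon with a double bond to nitrogen can shift the number: 3,5-dibromo-4-hydroxyphenyl in place of 2-(nitrooxy)phenyl gives a 2.8-fold higher number from compound 2 to compound 3 (0.45 log units; beyond the scatter) as the first step beyond the scatter. Compound 1 and compound 2, whose values lie within the scatter of each other, gave no sign of this. No measurement shown accounts for the step.

No compound shown separates the two bromine atoms from the hydroxy group of the entering aryl group. Also open, as far as these compounds go, is how an aryl group carrying an amine or a carboxylic acid would read at this place.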